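The compounds below may be only part of what the source reports. "The series", "measured", "known", "first", "only" and "open" are said of these compounds alone.

Measured so far in a functional assay on Vas deferens for antagonist activity at Alpha-1A adrenergic receptor (Rattus norvegicus); on this read-out lower numbers stand for lower potency and higher numbers for higher potency (the scale is a negative logarithm):
compound 1 `COc1cccc(OC)c1OCCNCCOc1ccccc1OCc1cccc(Cl)c1` — 8.12
compound 2 `COc1cccc(OC)c1OCCNCCOc1ccccc1OCc1ccc(Cl)cc1` — 8.17
compound 3 `COc1cccc(OC)c1OCCNCCOc1ccccc1OCc1ccc([N+](=O)[O-])cc1` — 8.58

Compound 3 carries the highest of the three numbers in this assay, and its lead over both neighbours lies beyond the scatter. The steps that reach it are a number 0.46 log units higher from compound 1 to compound 3 (beyond the scatter) and a number 0.41 log units higher from compound 2 to compound 3 (beyond the scatter), both of them changes on the same aryl group at the end of the benzyl ether; the step of a number 0.05 log units higher from compound 1 to compound 2 (within the scatter), which only moves the chloro substituent on that ring, stays within the scatter.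

Compound 4 `COc1ccccc1COc1ccccc1OCCNCCOc1c(OC)cccc1OC` changes the same position once more: 2-methoxyphenyl in place of 4-nitrophenyl on a saturated chain carbon bound to an oxygen on an aromatic ring. Going by the values given here, no measured step covers a methoxy group on that ring, nor a substituent at the 2-position. Among the compounds with values here, the only guide is that the two chloro analogues, compound 1 and compound 2, sit together below compound 3, while the nitro analogue alone stands higher. With the nitro group gone, compound 4 is expected to fall back toward the level of compound 1 and compound 2 rather than keep the gain of compound 3; the step of a number 0.38 log units lower from compound 3 to compound 4 (beyond the scatter) is the estimated size of that return in this assay, a modest loss, though the new group could equally leave the number within the scatter of compound 3. The expected value for compound 4 in this assay is therefore 8.2, with a range from 7.6 to 8.7.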

Compound 4, negative logarithm of the antagonist equilibrium constant: 8.53
The estimate for compound 4 lay 0.33 log units below the measured number; the range from low to high includes it.
By their numbers in this assay, from the lowest: compounds 1 and 2 (each within the scatter of the next); then compounds 4 and 3 (each within the scatter of the next).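

In this assay 2-methoxyphenyl in place of 4-nitrophenyl gives a number 0.05 log units lower from compound 3 to compound 4 (within the scatter) at this position, so the higher level is not confined to the nitro group. The same group also stands clear of both chloro analogues, with a number 0.36 log units higher from compound 2 to compound 4 (beyond the scatter) and a number 0.41 log units higher from compound 1 to compound 4 (beyond the scatter) as the steps, which leaves the two chlorophenyl groups as the lower pair among the four compounds. No measurement at hand accounts for this result.

Methoxy appears only as 2-methoxyphenyl and nitro only as 4-nitrophenyl, so the compounds shown do not separate the effect of the group from that of its place on the ring. On these data alone, it also stays open whether an amine or a carboxylic acid on this ring would hold the level of compound 3 and compound 4 in this assay or fall to that of the chloro analogues.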